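This account rests on a few compounds, and the source may have more. Where it says the series, first, only, none or still open, it means among the compounds named here.

Compound 1 `COc1cc(C(=O)O)ccc1OCCCCOc1ccc(C(=O)C(C)C)c(O)c1C` gives 113 nM in an assay on HEK293 cells for positive allosteric modulation of metabotropic glutamate receptor 2 (Rattus norvegicus), read by thallium flux, with a stated time of 2.5 min; a higher number here means that more compound is needed for the effect, a lower number that less compound is needed.
Compound 2 `Cc1cc(C(=O)O)ccc1OCCCCOc1ccc(C(=O)CC(C)C)c(O)c1C` gives 192 nM in this assay.
Compound 3 `Cc1c(OCCCCOc2ccc(C(=O)O)cc2Cl)ccc(C(=O)CC2CCCC2)c1O` gives 237 nM in this assay.

These three compounds share a core and differ only in a few substituents. Compound 2 has the second highest of the three numbers, but its neighbours lie close: compound 3 is nearest, and compound 1 is furthest, and both gaps stay within the usual scatter of repeated measurements. On the numbers shown, then, the three compounds cannot be told apart.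

Compound 4 `COc1cc(C(=O)O)ccc1OCCCCOc1ccc(C(=O)CC(C)C)c(O)c1C` has not yet been measured. It differs from compound 2 in one place: methoxy in place of methyl on an aromatic carbon — methoxy in place of methyl on an aromatic carbon of a six-membered aromatic ring of carbon only, ortho to a large group and meta to a carboxy group.

Going by the values given here, no pair of measured compounds differs by this single change alone, so no direct step is available. Compound 1 carries a methoxy at the same place, with a different ketone chain, and gives 113 nM, which is within the scatter of compound 2. The expectation is therefore a small step in this assay, if any, toward a slightly lower number, and not beyond the scatter: a 1.4-fold lower number from compound 2 to compound 4 (0.14 log units; within the scatter). Compound 4 is estimated at 140 nM, expected to fall between 60 nM and 330 nM.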

Compound 4, half-maximal effective concentration: 40 nM
Estimate against measurement, compound 4: 3.5-fold (0.54 log units) above; measured number outside the range, below it.
By their numbers in this assay, from the lowest: compound 4; then compounds 1, 2 and 3 (each within the scatter of the next, the first and the last beyond it).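

In this assay, going by these compounds alone, methoxy in place of methyl on this aromatic carbon, ortho to a large group and meta to a carboxy group, gives a 4.8-fold lower number from compound 2 to compound 4 (0.68 log units; beyond the scatter) and so is a step that stands clear of the scatter, something the earlier compounds could not show, since each of them differed from the others in more than one place. The ketone chain matters at the same time: isobutyl in place of isopropyl on a carbonyl carbon gives a 2.8-fold lower number from compound 1 to compound 4 (0.45 log units; beyond the scatter), so compound 4 stands apart from both of its single-change neighbours, and the lowest number here comes with methoxy and isobutyl together. Nothing available explains why either change moves the number, and each rests on one pair of compounds.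

Going by these compounds, whether an ethoxy or a hydroxy group on the same carbon would carry the step further, keep it, or lose it remains open. Also open, on these data alone, is whether methoxy would give a similar step with other ketone chains, such as a cyclopentylmethyl chain, or with a longer linking chain in the core.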